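Swapping Fluorine for Bromine on the Phenyl Tail

A few compounds are considered here, and "the series" means these few. Any claim that something is new, unique, unknown or untested is made for them only; others in the source may bear on it.

Three compounds share a common core and differ only in the group at the end of the oxygen-linked chain. Compound 1 `O=C(O)CCCO/N=c1/ccn([C@@H]2O[C@H](COP(=O)(O)OP(=O)(O)OP(=O)(O)O)[C@@H](O)[C@H]2O)c(=O)[nH]1` ends that chain in a carboxy group; in a functional assay on 1321-N1 cells for agonist activity at P2Y purinoceptor 6 (Homo sapiens), read by scintillation counting and inositol phosphate accumulation (on this read-out lower numbers stand for an effect already at smaller amounts and higher numbers for an effect only at larger amounts of compound), compound 1 gives 697 nM. Compound 2 `O=c1[nH]/c(=N\OCCCCc2ccccc2)ccn1[C@@H]1O[C@H](COP(=O)(O)OP(=O)(O)OP(=O)(O)O)[C@@H](O)[C@H]1O` ends it in a benzyl group, and in this assay compound 2 gives 251 nM, so that a 2.8-fold lower number from compound 1 to compound 2 (0.44 log units; beyond the scatter). Compound 3 `O=c1[nH]/c(=N\OCCCc2ccc(F)cc2)ccn1[C@@H]1O[C@H](COP(=O)(O)OP(=O)(O)OP(=O)(O)O)[C@@H](O)[C@H]1O` ends it in a 4-fluorophenyl group, and in this assay compound 3 gives 1210 nM. Compound 3 carries the highest number of the three, though only one gap is clear: a 1.7-fold higher number from compound 1 to compound 3 (0.24 log units; within the scatter), whereas a 4.8-fold higher number from compound 2 to compound 3 (0.68 log units; beyond the scatter).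

Compound 4 `O=c1[nH]/c(=N\OCCCc2ccc(Br)cc2)ccn1[C@@H]1O[C@H](COP(=O)(O)OP(=O)(O)OP(=O)(O)O)[C@@H](O)[C@H]1O` differs from compound 3 by bromo in place of fluoro on an aromatic carbon. Neither measured step speaks directly to this change; both steps reaching compound 3 exchange the whole group at the chain end, not a single substituent on the ring. Going by the values given here, with no measured step of this kind, the most defensible expectation is a small change in this assay, one that may not exceed the scatter. Compound 4 is therefore expected to give 1000 nM in this assay, within a range from 400 nM to 3000 nM. That estimate corresponds to an expected step of a 1.2-fold lower number from compound 3 to compound 4 (0.08 log units; within the scatter).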

Compound 4, half-maximal effective concentration: 225 nM
Beside the measured number, compound 4's estimate is 4.4-fold (0.65 log units) above it; measured number below the stated range.
By their numbers in this assay, from the lowest: compounds 4 and 2 (each within the scatter of the next); then compounds 1 and 3 (each within the scatter of the next).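

In this assay, going by these compounds alone, the steps among the earlier compounds exchanged the whole end of the chain, whereas this one alters a single atom, with bromo in place of fluoro on the aromatic carbon para to a large group, and that alone gives a clear step (a 5.4-fold lower number from compound 3 to compound 4 (0.73 log units; beyond the scatter)). The ring carbon therefore matters on this read-out, and the 4-bromophenyl end of compound 4 cannot be told apart from the benzyl end of compound 2 (a 1.1-fold lower number from compound 2 to compound 4 (0.05 log units; within the scatter)), while it stands clearly apart from the carboxy end of compound 1 (a 3.1-fold lower number from compound 1 to compound 4 (0.49 log units; beyond the scatter)). Nothing available here accounts for the difference between the two halogens, so the result stands as an observation without an explanation.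

With only fluoro and bromo at this carbon, two points cannot show whether a chloro or iodo group, a methyl group or a plain hydrogen would follow the bromo compound or the fluoro compound. Going by these compounds, it also remains open whether the gain from bromo would carry over to a longer chain, such as the one ending in a 4-bromophenyl group one carbon further out.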